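A few compounds are considered here, and "the series" means these few. Any claim that something is new, unique, unknown or untested is made for them only; others in the source may bear on it.

Measured so far in a functional assay on HL-60 cells (Homo sapiens) for inhibition, read by sulforhodamine B assay, with a stated time of 48 h, tested at 10 uM; on this read-out lower numbers stand for less inhibition and higher numbers for more inhibition at the one concentration tested (going by the name of the read-out):
compound 1 `c1cn2cc(-c3ccsc3)nc(-c3ccc4ncn(C5CCCCC5)c4c3)c2n1`: 18.5%
compound 2 `Brc1ccc(-c2cn3ccnc3c(-c3ccc4ncn(C5CCCCC5)c4c3)n2)cc1`: 23.2%

Among the compounds with values here, compound 2 stands highest of the two numbers in this assay, its only neighbour being compound 1, and the step of a number 4.7 percentage points higher from compound 1 to compound 2 (within the scatter) lies within the scatter, so the two values are not told apart. Compound 3 `c1csc(-c2cn3ccnc3c(-c3ccc4ncn(C5CCCCC5)c4c3)n2)c1` is not yet measured. Its change from compound 2 is thiophen-2-yl in place of 4-bromophenyl on an aromatic carbon. Within the data shown here, the one measured step that bears on it is a number 4.7 percentage points higher from compound 1 to compound 2 (within the scatter), which exchanged thiophen-3-yl for 4-bromophenyl at this carbon and moved the number by less than the scatter. Among the measured compounds shown here, compound 3 reverses that exchange in kind, returning a thiophene to the same carbon, though thiophen-2-yl rather than thiophen-3-yl; no measured pair shows the effect of that difference. Compound 3 is therefore expected to shift the number by a step of a number 4.2 percentage points lower from compound 2 to compound 3 (within the scatter), not beyond the scatter. The estimate for compound 3 in this assay is 19%, with a range from 8% to 30%.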

Compound 3, a percentage reported as inhibition, at one concentration (the size of the read-out at that concentration, not a potency): 26.6%
The estimate for compound 3 lay 7.6 percentage points below the measured number; the range from low to high includes it.
By their numbers in this assay, from the lowest: compounds 1, 2 and 3 (each within the scatter of the next).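

In this assay the aromatic carbon next to the ring nitrogen now carries three different groups, and none of the steps between them leaves the scatter: thiophen-2-yl in place of 4-bromophenyl gives a number 3.4 percentage points higher from compound 2 to compound 3 (within the scatter), and thiophen-2-yl in place of thiophen-3-yl gives a number 8.1 percentage points higher from compound 1 to compound 3 (within the scatter). Within the data shown here, the second step is the only pair that isolates the point of attachment of the thiophene, and at this one concentration the two thiophenes are not told apart, nor is either told apart from 4-bromophenyl. Nothing on hand offers an explanation for these readings.

Still open, on these data alone, is whether any group at this carbon can move the number beyond the scatter, for example an amine or a carboxylic acid. The compounds shown also leave open how the other parts of the shared core bear on the read-out.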